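Moving a Trifluoromethyl Group Along a Three-Armed Core

The source may hold more compounds than are shown below. What is called first, only, known or untested is meant among the compounds shown, and "the series" means these compounds.

Measured compounds:
compound 1 `Oc1cccc(-c2cc(-c3ccccc3C(F)(F)F)cc(-c3cccc(O)c3)n2)c1`: 15200 nM
compound 2 `Oc1cccc(-c2cc(-c3cccc(C(F)(F)F)c3)cc(-c3cccc(O)c3)n2)c1`: 12700 nM
compound 3 `Oc1ccc(-c2cc(-c3ccccc3C(F)(F)F)cc(-c3cccc(O)c3)n2)cc1`: 17400 nM

All three were tested in a functional assay on HeLa cells (Homo sapiens) for inhibition; a lower number here means a stronger inhibitor, a higher number a weaker inhibitor. Compound 1 gives 15200 nM there, compound 2 gives 12700 nM, and compound 3 gives 17400 nM. The three numbers lie close together: the step of a 1.2-fold lower number from compound 1 to compound 2 (0.08 log units; within the scatter) and the step of a 1.1-fold higher number from compound 1 to compound 3 (0.06 log units; within the scatter) are both small, so none of the three can be called more or less potent than another.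

Compound 2 arises from compound 1 by the change (3-(trifluoromethyl)phenyl in place of 2-(trifluoromethyl)phenyl on an aromatic carbon). Compound 3 arises from compound 1 by the change (4-hydroxyphenyl in place of 3-hydroxyphenyl on an aromatic carbon), which is how the core of compound 3 differs from the core of compound 1.

Compound 4 `Oc1ccc(-c2cc(-c3cccc(C(F)(F)F)c3)cc(-c3cccc(O)c3)n2)cc1` has not yet been measured. It arises from compound 3 by the change (3-(trifluoromethyl)phenyl in place of 2-(trifluoromethyl)phenyl on an aromatic carbon). For the measured compounds named here, this is the same kind of change as the one from compound 1 to compound 2, but not the same: in compound 1 the place is meta to two 3-hydroxyphenyl groups, while in compound 3 it is meta to a 3-hydroxyphenyl group and meta to a 4-hydroxyphenyl group.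

Because the earlier step of a 1.2-fold lower number from compound 1 to compound 2 (0.08 log units; within the scatter) stayed within the scatter, a similarly small step is expected here, a 1.2-fold lower number from compound 3 to compound 4 (0.08 log units; within the scatter). Compound 4 is therefore estimated at 14500 nM in this assay, with a likely range from 7000 nM to 30000 nM.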

Compound 4, half-maximal inhibitory concentration: 16200 nM
Compound 4: middle estimate off by 1.1-fold (0.05 log units), on the low side; measured number inside the range.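

In this assay, putting 3-(trifluoromethyl)phenyl in place of 2-(trifluoromethyl)phenyl gives a 1.1-fold lower number from compound 3 to compound 4 (0.03 log units; within the scatter), and this agrees with what the same change did on the other core: the same change on two cores in this assay, a 1.2-fold lower number (0.08 log units; within the scatter) from compound 1 to compound 2 and a 1.1-fold lower number (0.03 log units; within the scatter) from compound 3 to compound 4, 1.1-fold (0.05 log units) apart, within the scatter of two such steps

Putting 4-hydroxyphenyl in place of 3-hydroxyphenyl gives a 1.3-fold higher number from compound 2 to compound 4 (0.11 log units; within the scatter), and this change also agrees across its two cores: the same change on two cores in this assay, a 1.1-fold higher number (0.06 log units; within the scatter) from compound 1 to compound 3 and a 1.3-fold higher number (0.11 log units; within the scatter) from compound 2 to compound 4, 1.1-fold (0.05 log units) apart, within the scatter of two such steps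

So on these two cores, each change carries over in the plain sense that it stays small both times, but every step here lies within the scatter, which means the agreement is only between steps too small to tell apart from repeat-measurement noise. It does not show that a change with a clear effect would carry over in the same way, nor that these two changes would stay this small on any other core.

The compounds shown leave open whether an amine or a carboxylic acid in place of a hydroxyl group, or a nitrile in place of the trifluoromethyl group, would shift the number beyond the scatter at all. They also leave open what a longer chain in place of one of the hydroxyphenyl groups would do.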